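The source may report more compounds than this note shows. Statements on the series, on what has been measured and on what is new or still open speak of the compounds shown alone.

Of the compounds shown here, two have so far been measured in an assay for inhibition of NADPH oxidase 4 (Homo sapiens), read by chemiluminescence; on this read-out higher numbers stand for weaker inhibition and lower numbers for stronger inhibition. Compound 1 `CN1C(=S)N(C2CCCCC2)C(=O)/C1=C/c1ccc(N(C)C)cc1` gives 35600 nM. Compound 2 `CN1C(=S)N(c2ccc3c(c2)CCC3)C(=O)/C1=C/c1ccc(O)cc1O` gives 6830 nM, the lowest of the two numbers, and its gap to compound 1 lies beyond the usual scatter. Compound 3 `CN1C(=S)N(c2ccc3c(c2)CCC3)C(=O)/C1=C/c1ccc(N(C)C)cc1` has not yet been measured; compared with compound 2 it carries 4-(dimethylamino)phenyl in place of 2,4-dihydroxyphenyl on a double-bonded chain carbon bound to a double-bonded ring carbon. Compound 1 carries that same entering group and gives 35600 nM. A step toward a higher number, meaning weaker inhibition, is therefore expected, a 2.9-fold higher number from compound 2 to compound 3 (0.47 log units; beyond the scatter). Compound 3 is estimated to give about 20000 nM, within a range from 8000 nM to 60000 nM.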

Compound 3, inhibition constant: 13100 nM
The estimate for compound 3 lay 1.5-fold (0.18 log units) above the measured number, and the stated range covers the measured number.
By their numbers in this assay, from the lowest: compounds 2 and 3 (each within the scatter of the next); then compound 1.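

In this assay, putting 4-(dimethylamino)phenyl in place of 2,4-dihydroxyphenyl on the double-bonded chain carbon gives a 1.9-fold higher number from compound 2 to compound 3 (0.28 log units; within the scatter), so this change does not separate the two groups. With 4-(dimethylamino)phenyl held constant, 2,3-dihydro-1H-inden-5-yl in place of cyclohexyl on the ring nitrogen gives a 2.7-fold lower number from compound 1 to compound 3 (0.43 log units; beyond the scatter), a modest step that can now be read on its own. Nothing at hand explains either step. Still open, from the compounds shown here alone, is how a plain phenyl or a methoxyphenyl would behave on that chain carbon. Also open, going by these compounds, is how a benzyl group would behave on the ring nitrogen.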